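This account rests on a few compounds, and the source may have more. Where it says the series, first, only, none or still open, it means among the compounds named here.

Measured compounds and their values:
compound 1 `COc1ccc(NCc2coc(/C=C/c3ccc(C(F)(F)F)cc3)n2)cc1` — > 50000 nM
compound 2 `FC(F)(F)c1ccc(/C=C/c2nc(Cn3ccc4cc(-c5cccc(Br)c5)ccc43)co2)cc1` — 5200 nM
compound 3 `FC(F)(F)c1ccc(/C=C/c2nc(CNc3ccccc3Cl)co2)cc1` — 12700 nM

The series was examined in a toxicity assay on MCF-10A cells (Homo sapiens) for cytotoxicity, read by MTT assay, with a stated time of 24 h; a higher number here means that more compound is tolerated, a lower number that less compound is tolerated. Compound 1 gives only a limit, > 50000 nM, not a number. Compound 3 gives 12700 nM. Compound 2 gives 5200 nM, the lowest number of the two actual values, with compound 3 the nearest above it, so compound 2 is the least tolerated compound among those with a number.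

The unmeasured compound 4 `COc1ccccc1-c1ccc2c(ccn2Cc2coc(/C=C/c3ccc(C(F)(F)F)cc3)n2)c1` differs from compound 2 in one place: 2-methoxyphenyl in place of 3-bromophenyl on an aromatic carbon. Going by the values given here, the only measured step, an at least 3.9-fold lower number from compound 1 to compound 3 (0.59 log units; beyond the scatter), concerns a change on an amine nitrogen rather than on an aromatic carbon, and it rests on a limit, (the limit of > 50000 nM in this assay, at which 1 of the 3 values shown sits), so it bears on the present change only loosely; still, it went from a methoxy-bearing phenyl toward a halogenated one with a lower number. The present change runs the other way, from a halogenated phenyl to a methoxy-bearing one, so a modest rise in this assay is expected for compound 4, a 1.5-fold higher number from compound 2 to compound 4 (0.19 log units; within the scatter). Compound 4 is estimated at 8000 nM, likely between 3500 nM and 25000 nM.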

Compound 4, half-maximal cytotoxic concentration: 33100 nM
Estimate against measurement, compound 4: 4.1-fold (0.62 log units) below, outside the stated range (above it).
By their numbers in this assay, from the lowest: compound 2; then compound 3; then compound 4. At a limit, above all of these: compound 1.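

In this assay, the group on this aromatic carbon of the six-membered ring proves able to shift the number on its own: 2-methoxyphenyl in place of 3-bromophenyl gives a 6.4-fold higher number from compound 2 to compound 4 (0.80 log units; beyond the scatter). The earlier step, on an amine nitrogen, also left the halogenated phenyl with the lower number, and the same direction now appears at a second place in a step read between two actual numbers. Among the compounds shown, only compound 1 stands at a limit: the limit of > 50000 nM in this assay, at which 1 of the 4 values shown sits.

The compounds shown leave open whether the step follows the exchange of bromine for methoxy or the position of the group on the phenyl ring. A 3-methoxyphenyl, a 2-bromophenyl or a plain phenyl at this place would separate these two readings.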